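Extending the ethoxy chain of compound 1

This account rests on a few compounds, and the source may have more. Where it says the series, first, only, none or still open, it means among the compounds named here.

Compound 1 `CCO/C(O)=C1\C(C)=NC(C)=C([N+](=O)[O-])C1c1ccccn1` gives 5000 nM here
Compound 2 `CC1=NC(C)=C([N+](=O)[O-])C(c2ccccn2)/C1=C(\O)OC1CCCCC1` gives 842 nM; 5270 nM; 74.8 nM (3 entries) here

Within the data shown here, in a functional assay for inhibition, with Cavia porcellus as the target (a higher number here means a weaker inhibitor, a lower number a stronger inhibitor), compound 1 gives 5000 nM as its only number, and one further entry has no single number. Compound 2 spreads widely the several entries of compound 2 in this assay, 842 nM; 5270 nM; 74.8 nM (3 entries) and offers no direct comparison. Compound 3 `COCCO/C(O)=C1\C(C)=NC(C)=C([N+](=O)[O-])C1c1ccccn1` carries methoxy in place of hydrogen on a saturated chain carbon, two bonds along the chain from an oxygen on an unsaturated carbon and so turns ethoxy to 2-methoxyethoxy. Among the measured compounds shown here, no measured step tests this change, so the expected step of a 1.4-fold lower number from compound 1 to compound 3 (0.15 log units; within the scatter) stays within the usual scatter of this assay and has no firm direction. For compound 3 the estimate is 3500 nM with an expected range from 700 nM to 15000 nM in this measurement.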

Compound 3, half-maximal inhibitory concentration: 94700 nM
For compound 3 the middle estimate is 27-fold (1.43 log units) below the measured one; measured number above the stated range.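

Turning ethoxy to 2-methoxyethoxy gives a 19-fold higher number from compound 1 to compound 3 (1.28 log units; beyond the scatter) in this assay, so inhibition at this position can weaken sharply with a small addition to the chain. This position therefore does not accept every extension of the ethoxy chain. Single numbers still call for care, as one compound can spread widely in this assay: the several entries of compound 2 in this assay, 842 nM; 5270 nM; 74.8 nM (3 entries)

Going by these compounds, whether the loss follows from the added oxygen or from the added length stays open. A propoxy or butoxy chain, or a 2-aminoethoxy chain, in place of 2-methoxyethoxy would help separate these.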